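Branched amine in place of an ether-linked amine

The compounds below may be only part of what the source reports. "The series", "measured", "known", "first", "only" and "open" are said of these compounds alone.

Compound 1, `NCCOc1ccc([C@H]2CC[C@]3(CC2)OOC2(O3)C3CC4CC(C3)CC2C4)cc1`, gives < 7 mL.min-1.g-1 in an ADME assay on microsomes from liver (Homo sapiens) for metabolic stability, read by LC-MS, tested at 1 uM (a higher number here means faster removal of the compound, a lower number slower removal), a limit of the assay.
Compound 2, `NCCOCCOc1ccc([C@H]2CC[C@]3(CC2)OOC2(O3)C3CC4CC(C3)CC2C4)cc1`, gives < 7 mL.min-1.g-1 in this assay, again a limit.
Compound 3, `O[C@H]1CC[C@H](NCCCOc2ccc([C@H]3CC[C@]4(CC3)OOC3(O4)C4CC5CC(C4)CC3C5)cc2)CC1`, gives < 7 mL.min-1.g-1 in this assay, also a limit.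

Compound 2 therefore stands at the limit of this assay rather than at a number, and the same holds for the other two values shown: the limit of < 7 mL.min-1.g-1 in this assay, at which 3 of the 3 values shown sit. The steps a step that the two limits leave unreadable from compound 1 to compound 2, a step that the two limits leave unreadable from compound 1 to compound 3 and a step that the two limits leave unreadable from compound 2 to compound 3 are all left unreadable by these limits, so none of them gives a size that can be carried forward.

The account now turns to compound 4, `CC(C)(N)CCOc1ccc([C@H]2CC[C@]3(CC2)OOC2(O3)C3CC4CC(C3)CC2C4)cc1`, which is not yet measured. Its difference from compound 2 is 1-amino-1-methylethyl in place of 2-aminoethoxy on a saturated chain carbon, two bonds along the chain from an oxygen on an aromatic ring. For the measured compounds named here, no measured step bears on this change with a readable size; all that the three measured compounds show is that each of them sits at the limit of this assay. On that basis compound 4 is expected to remain at or near that limit, with no step beyond the scatter expected in a step that the limit leaves unreadable from compound 2 to compound 4. The estimate for compound 4 in this assay is 5 mL.min-1.g-1, with a range from 2 mL.min-1.g-1 to 14 mL.min-1.g-1.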

Compound 4, intrinsic clearance in microsomes: < 7 mL.min-1.g-1
Compound 4: a limit, no number (the forecaster's own chance of this, stated with the estimate: 70%); the middle value does not contradict the limit.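

Compound 4 joins compound 1, compound 2 and compound 3 at a limit in this assay, so no step from any of them to compound 4 can be read: the limit of < 7 mL.min-1.g-1 in this assay, at which 4 of the 4 values shown sit.

The compounds shown leave open how fast any of the four is actually removed, and whether 1-amino-1-methylethyl and 2-aminoethoxy differ at all in this respect.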